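The compounds below may be only part of what the source reports. "The series", "measured", "known", "first", "only" and "open" are said of these compounds alone.

The measured compounds, all tested in a functional assay on MDA-MB-231 cells (Homo sapiens) for cytotoxicity, read by MTT assay, with a stated time of 72 h; a lower number here means a stronger inhibitor, a higher number a weaker inhibitor:

Compound 1, `COc1cc2c(Oc3ccc(NC(=O)c4nn(-c5ccc(Br)cc5)c(=O)c5ccccc45)cc3F)ccnc2cc1OCCCN1CCCC1`, gives 1160 nM.
Compound 2, `COc1cc2c(Oc3ccc(NC(=O)c4nn(-c5ccccc5Br)c(=O)c5ccccc45)cc3F)ccnc2cc1OCCCN1CCCC1`, gives 1020 nM.
Compound 3, `COc1cc2c(Oc3ccc(NC(=O)c4nn(-c5ccc(Br)cc5)c(=O)c5ccccc45)cc3F)ccnc2cc1OCCCN1CCC(C)CC1`, gives 1160 nM.

The three share a large common framework, and they differ from one another in only two places. Compound 1 and compound 2 differ in the group carried on an aromatic nitrogen: 2-bromophenyl in place of 4-bromophenyl on an aromatic nitrogen. This change produced a 1.1-fold lower number from compound 1 to compound 2 (0.06 log units; within the scatter). Compound 1 and compound 3 differ at the far end of the chain that hangs off the aromatic ring oxygen: 4-methylpiperidin-1-yl in place of pyrrolidin-1-yl on a saturated chain carbon, three bonds along the chain from an oxygen on an aromatic ring. That change produced no change at the digits printed from compound 1 to compound 3 (within the scatter). Neither change moved the number beyond the ordinary scatter of this assay, so the three compounds sit close together.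

Compound 4, `COc1cc2c(Oc3ccc(NC(=O)c4nn(-c5ccccc5Br)c(=O)c5ccccc45)cc3F)ccnc2cc1OCCCN1CCC(C)CC1`, has not yet been measured in this assay. It carries the core of compound 3 and differs from it in one place: 2-bromophenyl in place of 4-bromophenyl on an aromatic nitrogen. For the measured compounds named here, this is the same change as the one from compound 1 to compound 2, made at the same place, and it is the only occurrence of that change among the measured pairs. Because the step from compound 1 to compound 2 was a 1.1-fold lower number from compound 1 to compound 2 (0.06 log units; within the scatter), the expectation is that the step from compound 3 to compound 4 will be of similar size, estimated as a 1.1-fold lower number from compound 3 to compound 4 (0.04 log units; within the scatter). On that basis compound 4 is estimated to give about 1050 nM in this assay, with a likely range from 500 nM to 2200 nM.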

Compound 4, half-maximal inhibitory concentration: 1240 nM
Beside the measured number, compound 4's estimate is 1.2-fold (0.07 log units) below it; low and high end bracket the measured number.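

In this assay, putting 2-bromophenyl in place of 4-bromophenyl on the core of compound 3 gave a 1.1-fold higher number from compound 3 to compound 4 (0.03 log units; within the scatter), and this step agrees with the one seen earlier on the other core: the same change on two cores in this assay, a 1.1-fold lower number (0.06 log units; within the scatter) from compound 1 to compound 2 and a 1.1-fold higher number (0.03 log units; within the scatter) from compound 3 to compound 4, 1.2-fold (0.08 log units) apart, within the scatter of two such steps
Putting 4-methylpiperidin-1-yl in place of pyrrolidin-1-yl, now with 2-bromophenyl on the aromatic nitrogen, gave a 1.2-fold higher number from compound 2 to compound 4 (0.08 log units; within the scatter), and this too agrees with its earlier counterpart: the same change on two cores in this assay, no change at the digits printed (within the scatter) from compound 1 to compound 3 and a 1.2-fold higher number (0.08 log units; within the scatter) from compound 2 to compound 4, 1.2-fold (0.08 log units) apart, within the scatter of two such steps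
For the compounds shown here, both changes therefore carried from one core to the other without any shift that this assay can detect, but every step involved lies within the scatter, and each change was seen on only two cores, which does not show that a change with a real effect on the number would carry across by the same amount.

The compounds shown leave open whether a different group on the aromatic nitrogen, such as an unsubstituted phenyl or a chlorophenyl, or a different amine at the end of the chain, such as morpholine or piperazine, would move the number beyond the scatter. They also leave open what a shorter or longer chain between the ring oxygen and the amine would do.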